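Sulfonyl aryl substituent: bromo to cyano in the core

The source may report more compounds than this note shows. Statements on the series, on what has been measured and on what is new or still open speak of the compounds shown alone.

Compound 1 `Cc1ccc(S(=O)(=O)N2C/C(=C\c3cccc(F)c3)C(=O)/C(=C/c3cccc(F)c3)C2)cc1` carries a methyl on the sulfonyl-bearing ring and gives 3500 nM in a functional assay on HepG2 cells (Homo sapiens) for cytotoxicity, read by MTT assay, with a stated time of 24 h; on this read-out higher numbers stand for weaker inhibition and lower numbers for stronger inhibition. Compound 2 `O=C1/C(=C/c2cccc(F)c2)CN(S(=O)(=O)c2ccc(F)cc2)C/C1=C\c1cccc(F)c1` gives 5000 nM in this assay, and compound 3 `O=C1/C(=C/c2cccc(F)c2)CN(S(=O)(=O)c2ccc(Br)cc2)C/C1=C\c1cccc(F)c1` gives 7700 nM. Compound 3 stands at the highest of the three numbers; the step of a 1.5-fold higher number from compound 2 to compound 3 (0.19 log units; within the scatter) lies within the scatter, while the step of a 2.2-fold higher number from compound 1 to compound 3 (0.34 log units; beyond the scatter) is modest but beyond it. The step of a 1.4-fold higher number from compound 1 to compound 2 (0.15 log units; within the scatter) is within the scatter.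

Compound 4 `N#Cc1ccc(S(=O)(=O)N2C/C(=C\c3cccc(F)c3)C(=O)/C(=C/c3cccc(F)c3)C2)cc1` is obtained from compound 3 by the change (cyano in place of bromo on an aromatic carbon). The three measured steps all swap the group at this same position and move the number only slightly, the largest being the modest step from compound 1 to compound 3. Going by the values given here, no measured compound carries a cyano at this place, so direction is uncertain; the expected step of a 1.1-fold lower number from compound 3 to compound 4 (0.04 log units; within the scatter) is estimated to be small, most likely within the scatter, around the value of compound 3. Compound 4 is therefore expected to give about 7000 nM in this assay, with a range from 3000 nM to 16000 nM.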

Compound 4, half-maximal inhibitory concentration: 2600 nM
Compound 4: middle estimate off by 2.7-fold (0.43 log units), on the high side, outside the stated range (below it).
By their numbers in this assay, from the lowest: compounds 4, 1, 2 and 3 (each within the scatter of the next, the first and the last beyond it).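

In this assay, going by these compounds alone, cyano and bromo at this position are the first pair to separate with cyano on the lower side: a 3.0-fold lower number from compound 3 to compound 4 (0.47 log units; beyond the scatter) is modest but beyond the scatter. The cyano compound does not separate from the other two groups, since a 1.9-fold lower number from compound 2 to compound 4 (0.28 log units; within the scatter) and a 1.3-fold lower number from compound 1 to compound 4 (0.13 log units; within the scatter) both lie within the scatter, so among these four compounds only compound 3 stands apart from compound 4 and from compound 1. Nothing shown here gives a reason for the gap between bromo and cyano.

From the compounds shown here alone, whether an amine or a carboxylic acid at this place would move the number beyond the span of these four compounds stays open. Also open, going by these compounds, is whether the step from bromo to cyano would hold with other groups elsewhere on the shared core.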